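The source may hold more compounds than are shown below. What is called first, only, known or untested is meant among the compounds shown, and "the series" means these compounds.

Compound 1 `COc1ccc(-c2nc(-c3c[nH]c4ccccc34)co2)cc1OC`: 278000 nM
Compound 2 `c1ccc2c(-c3coc(-c4ccncc4)n3)c[nH]c2c1`: 238000 nM
Compound 3 `COc1ccc(-c2nc(-c3c[nH]c4ccccc34)co2)cc1`: 507000 nM

In a functional assay on LNCaP cells (Homo sapiens) for cytotoxicity, read by MTT assay, with a stated time of 48 h (on this read-out higher numbers stand for weaker inhibition and lower numbers for stronger inhibition), compound 1 gives 278000 nM, and all three numbers sit close together. Compound 2 gives 238000 nM, a value that differs from compound 1 only within the usual scatter, and the single-point change from compound 1 to compound 3 produced a 1.8-fold higher number from compound 1 to compound 3 (0.26 log units; within the scatter). The new compound 4 `COc1cc(-c2nc(-c3c[nH]c4ccccc34)co2)ccc1O` differs from compound 1 by hydrogen in place of methyl on an oxygen on an aromatic ring. Among the measured compounds shown here, the only comparable measured step, removing a whole methoxy, stayed within the scatter, so removing just its methyl is expected to leave the number about where compound 1 stands, with no shift beyond the scatter in either direction. Compound 4 is therefore estimated at 280000 nM, between 120000 nM and 650000 nM, which means an expected step of a 1.0-fold higher number from compound 1 to compound 4 (0.00 log units; within the scatter).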

Compound 4, half-maximal inhibitory concentration: 445000 nM
Compound 4: middle estimate off by 1.6-fold (0.20 log units), on the low side; measured number inside the range.
By their numbers in this assay, from the lowest: compounds 2, 1, 4 and 3 (each within the scatter of the next, the first and the last beyond it).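

Compound 4 alters the methoxy that compound 3 keeps, so a second methoxy group of compound 1 has now been tested. In this assay replacing it with hydroxy gives a 1.6-fold higher number from compound 1 to compound 4 (0.20 log units; within the scatter) and so this small change at the oxygen does not clearly move the number. Neither methoxy of compound 1 has yet shown a shift beyond the scatter, and nothing available explains this result. Still open, going by these compounds, is whether an amine or a longer chain such as ethoxy in this place would move the number beyond the scatter.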